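Fluoro in Place of Hydrogen: What to Expect for Compound 4

The source may report more compounds than this note shows. Statements on the series, on what has been measured and on what is new or still open speak of the compounds shown alone.

Three compounds have been measured in a functional assay on MCF7 cells (Homo sapiens) for antiproliferative activity, read by MTT assay, with a stated time of 72 h; a lower number here means a stronger inhibitor, a higher number a weaker inhibitor:

Compound 1 `Nc1nc(N)c2cc(CSC(=S)N3CCN(c4ccccc4)CC3)ccc2n1`: 2950 nM
Compound 2 `COc1ccc(N2CCN(C(=S)SCc3ccc4nc(N)nc(N)c4c3)CC2)cc1`: 1580 nM
Compound 3 `Cc1ccccc1N1CCN(C(=S)SCc2ccc3nc(N)nc(N)c3c2)CC1`: 4230 nM

Among these three numbers compound 1 stands second highest. Its nearest neighbour is compound 3, a 1.4-fold higher number from compound 1 to compound 3 (0.16 log units; within the scatter), and its furthest is compound 2, a 1.9-fold lower number from compound 1 to compound 2 (0.27 log units; within the scatter); both of these steps lie within the scatter, so the three compounds cannot be ranked against each other in this assay. Going by the values given here, the only step beyond the scatter is a 2.7-fold higher number from compound 2 to compound 3 (0.43 log units; beyond the scatter), and it is modest.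

Compound 4 `Nc1nc(N)c2cc(CSC(=S)N3CCN(c4ccc(F)cc4)CC3)ccc2n1` shares the core of compound 1 and differs from it in one place: fluoro in place of hydrogen on an aromatic carbon. The closest measured comparisons are the two steps that also add a single small group on the same aromatic ring of compound 1, namely a 1.9-fold lower number from compound 1 to compound 2 (0.27 log units; within the scatter) and a 1.4-fold higher number from compound 1 to compound 3 (0.16 log units; within the scatter), and neither of them moved the number beyond the scatter. On that basis no step beyond the scatter is expected from compound 1 to compound 4 in this assay, so that the expected step is a 1.1-fold lower number from compound 1 to compound 4 (0.05 log units; within the scatter). Compound 4 is therefore estimated to give 2600 nM, within a range from 1200 nM to 5600 nM.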

Compound 4, half-maximal inhibitory concentration: 1920 nM
Compound 4: the middle estimate sits 1.4-fold (0.13 log units) above what was measured; the measured number falls inside the stated range.
By their numbers in this assay, from the lowest: compounds 2, 4, 1 and 3 (each within the scatter of the next, the first and the last beyond it).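

In this assay, fluoro on an aromatic carbon para to a large group gives a third single-group change on the ring of compound 1 that stays within the scatter (a 1.5-fold lower number from compound 1 to compound 4 (0.19 log units; within the scatter)), so at this place fluoro cannot be told apart from hydrogen. Fluoro also cannot be told apart from methoxy at that place (a 1.2-fold higher number from compound 2 to compound 4 (0.08 log units; within the scatter)), which means two quite different groups there give numbers that cannot be separated. What is new is a second step beyond the scatter, though a modest one (a 2.2-fold lower number from compound 3 to compound 4 (0.34 log units; beyond the scatter)): compound 4, like compound 2 (a 2.7-fold higher number from compound 2 to compound 3 (0.43 log units; beyond the scatter)), now stands apart from the 2-methylphenyl compound 3, while compound 1, with its plain phenyl, goes against any neat split, as it lies within the scatter of all three.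

Nothing shown here gives a reason for these differences. As far as these compounds go, it also stays open whether a trifluoromethyl, an amine or a carboxylic acid at this place would move the number beyond the scatter from compound 1, and whether fluoro elsewhere on the ring would behave as it does here.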